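The source may report more compounds than this note shows. Statements on the series, on what has been measured and on what is new or still open speak of the compounds shown alone.

Compound 1 `CC(C)OCCCNC(=O)c1csc(Nc2cc(Cl)c(Cl)c(Cl)c2)n1` was tested in an ADME assay on MDCK cells (Canis lupus familiaris) for cytotoxicity, with a stated time of 48 h; a higher number here means that more compound is tolerated, a lower number that less compound is tolerated. In this assay compound 1 gives > 100000 nM, which is a limit of the assay rather than a number. Compound 2 `CCOCCCNC(=O)c1csc(Nc2cc(Cl)c(Cl)c(Cl)c2)n1` differs from compound 1 in one place, by hydrogen in place of methyl on a saturated chain carbon bound to an oxygen on a saturated carbon and a saturated chain carbon. In this assay compound 2 gives > 100000 nM, again a limit and not a number. Both values sit at the limit of > 100000 nM in this assay, at which 3 of the 3 values shown sit, so the step that the two limits leave unreadable from compound 1 to compound 2 cannot be read from them. Compound 3 `CC(C)OCCCNC(=O)c1csc(Nc2ccc(Cl)c(F)c2)n1` carries the same chain as compound 1 on a different core; the difference between the two cores is not broken down here. In this assay compound 3 gives > 100000 nM, also a limit. Compound 4 `CCOCCCNC(=O)c1csc(Nc2ccc(Cl)c(F)c2)n1` has not yet been measured; it differs from compound 3 by hydrogen in place of methyl on a saturated chain carbon bound to an oxygen on a saturated carbon and a saturated chain carbon, which is the same change as that from compound 1 to compound 2, made at the same place. Within the data shown here, the step from compound 3 to compound 4 is expected to be small, about a step that the limit leaves unreadable from compound 3 to compound 4, because every value measured so far sits at the limit of > 100000 nM in this assay, at which 3 of the 3 values shown sit, and the one measured step of this kind, a step that the two limits leave unreadable from compound 1 to compound 2, gave no readable shift away from that limit. Compound 4 is therefore expected to give about 150000 nM in this assay, with the estimate ranging from 100000 nM to 300000 nM, and most likely to be reported only as a limit.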

Compound 4, half-maximal cytotoxic concentration: > 100000 nM
Compound 4 was reported as a limit; the forecaster's own chance of this, stated with the estimate: 85%; the middle value is on the limit's open side.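

In this assay compound 4 gives > 100000 nM as a limit and not a number. Compound 3 also stands at a limit, so the step between compound 3 and compound 4 cannot be read. Still open is the concentration at which any of these compounds harms the cells, and whether isopropoxy to ethoxy changes it, because the values shown give only this: the limit of > 100000 nM in this assay, at which 4 of the 4 values shown sit.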